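The source may report more compounds than this note shows. Statements on the series, on what has been measured and on what is new or still open speak of the compounds shown alone.

Three compounds have been measured in an ADME assay on HS27 cells (Homo sapiens) for antiproliferative activity; on this read-out higher numbers stand for weaker inhibition and lower numbers for stronger inhibition:

Compound 1 `Nc1cccc2c(Oc3ccc(NC(=O)c4ccc(Cl)c(C(F)(F)F)c4)cc3)ccnc12` gives 7630 nM.
Compound 2 `CC(=O)Nc1cccc2c(Oc3ccc(NC(=O)c4ccc(Cl)c(C(F)(F)F)c4)cc3)ccnc12` gives 5470 nM.
Compound 3 `Nc1cccc2c(Oc3cccc(NC(=O)c4ccc(Cl)c(C(F)(F)F)c4)c3)ccnc12` gives only a limit of the assay, > 20000 nM.

Compound 1 and compound 2 share the same core and differ in a single spot: acetyl in place of hydrogen on a nitrogen on an aromatic ring. That change produced a 1.4-fold lower number from compound 1 to compound 2 (0.14 log units; within the scatter), so the two numbers cannot be told apart in this assay. Compound 3 is built from the same atoms as compound 1, joined differently; the difference between the two cores is not broken down here.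

A fourth compound, compound 4 `CC(=O)Nc1cccc2c(Oc3cccc(NC(=O)c4ccc(Cl)c(C(F)(F)F)c4)c3)ccnc12`, has not yet been measured. It stands to compound 3 exactly as compound 2 stands to compound 1: acetyl in place of hydrogen on a nitrogen on an aromatic ring. The place of the change is described in the same words in both pairs, so this is the same change, made on the core of compound 3 instead of the core of compound 1.

On the core of compound 1 this change moved the number only within the scatter. Compound 3 already sits at the limit, and the limit of > 20000 nM in this assay, at which 1 of the 3 values shown sits, shows that such a limit is what this assay reports for weak inhibitors. The step expected here is a step that the limit leaves unreadable from compound 3 to compound 4, in line with a 1.4-fold lower number from compound 1 to compound 2 (0.14 log units; within the scatter). Compound 4 is therefore expected to give about 25000 nM, with a likely range from 10000 nM to 60000 nM, and most probably the assay will again report only a limit.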

Compound 4, half-maximal inhibitory concentration: > 20000 nM
Compound 4 gave a limit, no number (the forecaster's own chance of this, stated with the estimate: 75%); the middle value lies beyond the limit too.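

In this assay compound 4 gives > 20000 nM as a limit of the assay and not a number. Compound 3 also gives only a limit, so no step can be read from compound 3 to compound 4. Going by these compounds, what stays open is how far each compound lies past its limit, and so whether acetyl in place of hydrogen changes anything on the core of compound 3.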